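A few compounds are considered here, and "the series" means these few. Any claim that something is new, unique, unknown or untested is made for them only; others in the source may bear on it.

Measured so far:
compound 1 `COc1cc2c(Oc3ccc(NC(=O)c4nnn(-c5ccc(F)cc5)c4C(F)(F)F)cc3F)ccnc2cc1OCCCN1CCCC1`
compound 2 `COc1cc2c(Oc3ccc(NC(=O)c4nnn(-c5ccc(F)cc5)c4C(F)(F)F)cc3F)ccnc2cc1OCCCN1CCCCC1`

In a functional assay on MKN-45 cells (Homo sapiens) for cytotoxicity, read by MTT assay, with a stated time of 72 h (on this read-out higher numbers stand for weaker inhibition and lower numbers for stronger inhibition), compound 1 gives 21 nM and compound 2 gives 40 nM. Compound 2 sits at the upper of the two numbers, though a 1.9-fold higher number from compound 1 to compound 2 (0.28 log units; within the scatter) lies within the scatter, so the two compounds cannot be told apart. Compound 3 `COc1cc2c(Oc3ccc(NC(=O)c4nnn(-c5ccc(F)cc5)c4C(F)(F)F)cc3F)ccnc2cc1OCCCN1CCC(C)CC1` is not yet measured; it differs from compound 2 by methyl in place of hydrogen on a saturated ring carbon. For the measured compounds named here, the one step measured so far, a 1.9-fold higher number from compound 1 to compound 2 (0.28 log units; within the scatter), alters the same saturated ring and stays within the scatter, so no step beyond the scatter is expected in this assay here. Compound 3 is estimated at 45 nM, range 18 nM to 115 nM, which means an expected 1.1-fold higher number from compound 2 to compound 3 (0.05 log units; within the scatter).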

Compound 3, half-maximal inhibitory concentration: 70 nM
Beside the measured number, compound 3's estimate is 1.6-fold (0.19 log units) below it, and the stated range covers the measured number.
By their numbers in this assay, from the lowest: compounds 1, 2 and 3 (each within the scatter of the next, the first and the last beyond it).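

Methyl on the saturated ring carbon three ring bonds from the ring nitrogen does not separate compound 3 from its parent in this assay (a 1.8-fold higher number from compound 2 to compound 3 (0.24 log units; within the scatter)). For the compounds shown here, the change from pyrrolidin-1-yl to 4-methylpiperidin-1-yl gives the first step beyond the scatter, though a modest one (a 3.3-fold higher number from compound 1 to compound 3 (0.52 log units; beyond the scatter)), so the ring change and methyl taken together can be told apart where neither single step can. No measurement here bears on the origin of either step.
Open, going by these compounds, is how a hydroxyl, an ethyl or a dimethylamino group would read at this same ring carbon. Also open, on these data alone, is whether a morpholine in place of the piperidine ring would stay within the scatter of compound 2.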